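The source may report more compounds than this note shows. Statements on the series, on what has been measured and on what is new or still open speak of the compounds shown alone.

Measured so far in a functional assay on HL-60 cells (Homo sapiens) for inhibition, read by CCK-8 assay, with a stated time of 48 h; a higher number here means a weaker inhibitor, a lower number a stronger inhibitor:
- compound 1 `Cc1ccc(S(=O)(=O)Oc2ccccc2/C=C(\C#N)C(=O)Nc2nnc(C)s2)cc1`: 11500 nM
- compound 2 `COc1ccc(S(=O)(=O)Oc2ccccc2/C=C(\C#N)C(=O)Nc2nnc(-c3cccs3)s2)cc1`: 5230 nM
- compound 3 `Cc1ccc(S(=O)(=O)Oc2cccc(/C=C(\C#N)C(=O)Nc3nnc(C)s3)c2)cc1`: 5780 nM

Compound 3, at 5780 nM, lies within the usual scatter of both other compounds, so this assay does not separate it from either. Compound 4 `Cc1ccc(S(=O)(=O)Oc2cccc(/C=C(\C#N)C(=O)Nc3nnc(-c4cccs4)s3)c2)cc1` is the next to be read. It differs from compound 3 by thiophen-2-yl in place of methyl on an aromatic carbon, with thiophen-2-yl in place of methyl on an aromatic carbon.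

For the measured compounds named here, no measured pair isolates this change, so the evidence is indirect. Compound 2, which carries thiophen-2-yl, gives 5230 nM, and compound 1, which carries methyl, gives 11500 nM, but these two also differ elsewhere. A modest move towards a lower number is therefore expected, possibly not much beyond the scatter. The estimated step is a 1.8-fold lower number from compound 3 to compound 4 (0.26 log units; within the scatter). For compound 4 the expected value is 3200 nM, with an estimated range of 1200 nM to 8000 nM.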

Compound 4, half-maximal inhibitory concentration: 8750 nM
Beside the measured number, compound 4's estimate is 2.7-fold (0.44 log units) below it; measured number outside the range, above it.
By their numbers in this assay, from the lowest: compounds 2, 3, 4 and 1 (each within the scatter of the next, the first and the last beyond it).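

In this assay, the first direct test of this exchange gives a 1.5-fold higher number from compound 3 to compound 4 (0.18 log units; within the scatter), so the 5-methyl-1,3,4-thiadiazol-2-yl and 5-(thiophen-2-yl)-1,3,4-thiadiazol-2-yl forms are not separated. This position therefore accepts a thiophen-2-yl ring in place of methyl, four more heavy atoms and an added ring, with no change that this assay can resolve in this pair. No measurement bears on why the exchange leaves the reading within the scatter.

It remains open whether the same exchange would also read within the scatter on the core of compound 1, for which no matched partner is shown. Also open, on these data alone, is how this carbon would respond to a phenyl ring, a primary amine, a carboxylic acid or a longer alkyl chain.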